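This account rests on a few compounds, and the source may have more. Where it says the series, first, only, none or still open, it means among the compounds named here.

Measured so far:

Compound 1 `CC(C)N(Cc1cccc(OCCCCCC(=O)O)c1)C(=O)c1ccc(-c2ccco2)cc1`: in an ADME assay on HepG2 cells (Homo sapiens) for cytotoxicity, read by CellTiter-Glo and resazurin assay, with a stated time of 72 h (on this read-out higher numbers stand for an effect only at larger amounts of compound and lower numbers for an effect already at smaller amounts), compound 1 gives > 26000 nM, which is a limit of the assay and not a number.
Compound 2 `CC(C)Oc1cccc(-c2ccc(C(=O)N(Cc3cccc(OCCCCCC(=O)O)c3)C(C)C)cc2)c1`: in this assay compound 2 gives > 26000 nM, again a limit of the assay.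
Compound 3 `CCOC(=O)CCCCCOc1cccc(CN(C(=O)c2ccc(-c3cccc(OC(C)C)c3)cc2)C(C)C)c1`: in this assay compound 3 gives > 26000 nM, also a limit of the assay.

Compound 4 `CCOC(=O)CCCCCOc1cccc(CN(C(=O)c2ccc(-c3ccco3)cc2)C(C)C)c1` has not yet been measured. It differs from compound 3 by furan-2-yl in place of 3-isopropoxyphenyl on an aromatic carbon. The same change has already been made once among the measured compounds, from compound 2 to compound 1, described as furan-2-yl in place of 3-isopropoxyphenyl on an aromatic carbon; the step it made in this assay is a step that the two limits leave unreadable from compound 2 to compound 1. The two places carry the same wording, so it is the same change. The cores of compound 3 and compound 2 differ by ethyl in place of hydrogen on an oxygen next to a carbonyl group.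

Going by the values given here, for compound 4 the step from compound 3 is expected to be a step that the limit leaves unreadable from compound 3 to compound 4, a guess that rests on (the limit of > 26000 nM in this assay, at which 3 of the 3 values shown sit), where every measured value of this series so far sits. Compound 4 is therefore estimated to come out around 40000 nM, most likely again only as a limit, within a range from 20000 nM to 100000 nM.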

Compound 4, half-maximal effective concentration: > 26000 nM
Compound 4: only a limit was reported; the forecaster's own chance of this, stated with the estimate: 85%; the middle value lies beyond the limit too.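

In this assay compound 4 gives > 26000 nM, a limit of the assay and not a number. No step can be read from compound 3 or compound 1 to compound 4: the limit of > 26000 nM in this assay, at which 4 of the 4 values shown sit. The compounds shown leave open whether furan-2-yl in place of 3-isopropoxyphenyl, or ethyl in place of hydrogen, changes the effect on these cells at all.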